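The source may hold more compounds than are shown below. What is called first, only, known or untested is meant among the compounds shown, and "the series" means these compounds.

Working notes on the series. In a functional assay (aorta) with Rattus norvegicus as the target (a lower number here means a stronger inhibitor, a higher number a weaker inhibitor), compound 2 `CCOC(=O)CN(c1ccccc1)[C@H]1c2cc(C#N)ccc2OC(C)(C)[C@@H]1O` gives only a limit, > 30000 nM. Compound 1 `CCOC(=O)CN(c1ccccc1)C1c2cc(C#N)ccc2OC(C)(C)C1O`, the same atoms drawn without configurations, also gives only a limit, > 30000 nM. Compound 3 `CCOC(=O)CN(c1nc(C)cs1)[C@H]1c2cc(C#N)ccc2OC(C)(C)[C@@H]1O` gives 84000 nM in this assay. The step that the two limits leave unreadable from compound 1 to compound 2 is unreadable because of the fact that one of compounds 1 and 2 is drawn with a defined configuration and the other without, at the place where they differ, and the step that the limit leaves unreadable from compound 2 to compound 3 is unreadable because of the limit of > 30000 nM in this assay, at which 2 of the 3 values shown sit. Compound 4 `CCOC(=O)NN(c1ccccc1)[C@H]1c2cc(C#N)ccc2OC(C)(C)[C@@H]1O` differs from compound 2 by (ethoxycarbonyl)amino in place of (ethoxycarbonyl)methyl on a nitrogen on an aromatic ring. No measured step touches this position, and the two shown steps carry no readable size, so no direction can be drawn from them. The step is estimated at a step that the limit leaves unreadable from compound 2 to compound 4, expected within the scatter. Compound 4 is expected to give 45000 nM, between 10000 nM and 200000 nM, most likely again as a limit in this assay.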

Compound 4, half-maximal inhibitory concentration: 2200 nM
The estimate for compound 4 lay 20-fold (1.31 log units) above the measured number; the measured number lies below the stated range.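

In this assay, the substituent on the nitrogen on an aromatic ring gives the first readable step among the compounds shown: (ethoxycarbonyl)amino in place of (ethoxycarbonyl)methyl gives an at least 13-fold lower number from compound 2 to compound 4 (1.13 log units; beyond the scatter). The swap leaves the heavy-atom count unchanged and adds a hydrogen-bond donor. Compound 2 gives only a limit, so the step has a bound and no exact size, because of this: the limit of > 30000 nM in this assay, at which 2 of the 4 values shown sit.

Whether the added donor accounts for the step stays open. Also open, as far as these compounds go, is how a carboxylic acid or a longer chain would read at this position.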